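Swapping a chlorophenyl for an aminothiazole in a triaryl carbinol

The source may hold more compounds than are shown below. What is called first, only, known or untested is meant among the compounds shown, and "the series" means these compounds.

Compound 1 `OC(c1ccc(Cl)cc1)(c1cccnc1)c1ccccc1Cl` is tested in an ADME assay on L6 cells (Rattus norvegicus) for cytotoxicity, read by resazurin assay, with a stated time of 72 h (a higher number here means a weaker inhibitor, a lower number a stronger inhibitor), where compound 1 gives 61300 nM. Among the two measured compounds this is the lowest number; its nearest neighbour is compound 2 `NC(c1ccc(Cl)cc1)(c1cccnc1)c1ccccc1Cl`, which gives 76000 nM, and the step of a 1.2-fold higher number from compound 1 to compound 2 (0.09 log units; within the scatter) lies within the scatter. Compound 3 `Nc1ncc(C(O)(c2ccc(Cl)cc2)c2cccnc2)s1` differs from compound 1 by 2-amino-1,3-thiazol-5-yl in place of 2-chlorophenyl on a saturated chain carbon bound to two aromatic carbons and an oxygen on a saturated carbon. Among the compounds with values here, the only measured step concerns the carbinol substituent, not the aryl ring, so nothing measured bears directly on this change. Compound 3 is therefore expected at about 80000 nM, between 30000 nM and 200000 nM, an estimated step of a 1.3-fold higher number from compound 1 to compound 3 (0.12 log units; within the scatter) not clearly beyond the scatter.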

Compound 3, half-maximal inhibitory concentration: 56000 nM
Beside the measured number, compound 3's estimate is 1.4-fold (0.15 log units) above it; measured number inside the range.
By their numbers in this assay, from the lowest: compounds 3, 1 and 2 (each within the scatter of the next).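

In this assay, 2-amino-1,3-thiazol-5-yl in place of 2-chlorophenyl gives a 1.1-fold lower number from compound 1 to compound 3 (0.04 log units; within the scatter). The earlier step concerned only the hydroxy and amino groups, whereas this one shows that a five-membered aromatic ring with 2 hetero atoms can stand at this position with no step beyond the scatter. Nothing available offers an explanation for this result. As far as these compounds go, it remains open whether a methyl group or an unsubstituted phenyl at this carbon would also stay within the scatter, and whether the amino group on the thiazole matters at all.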